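Ring swap on the thiocarbonyl carbon of compound 2

The compounds below may be only part of what the source reports. "The series", "measured", "known", "first", "only" and "open" are said of these compounds alone.

Measured so far in a functional assay on MCF7 cells (Homo sapiens) for cytotoxicity, read by MTT assay, with a stated time of 72 h, tested at 100 uM; a higher number here means more inhibition of growth at the concentration tested, a lower number less inhibition of growth:
compound 1 `N/C(=N\NC(=S)N1CCOCC1)c1ccccn1` gives 81.6%
compound 2 `Cc1ccnc(/C(N)=N/NC(=S)N2CCOCC2)c1` gives 12.8%
compound 3 `N/C(=N\NC(=S)N1CCCCCC1)c1ccc(F)cn1` gives 79%

Compound 2 stands lowest of the three. Within the data shown here, the only single-point step known, a number 68.8 percentage points lower from compound 1 to compound 2 (beyond the scatter), concerns a methyl group, not the ring on the thiocarbonyl carbon. Compound 3 differs from compound 2 in more than one place, so its higher value cannot be tied to the ring alone.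

Compound 4 `Cc1ccnc(/C(N)=N/NC(=S)N2CCCC2)c1` differs from compound 2 by pyrrolidin-1-yl in place of morpholin-4-yl on a thiocarbonyl carbon. Among the measured compounds shown here, no measured step isolates this change, so the direction is uncertain; a step of moderate size in this assay is possible either way, with a rise somewhat more plausible than a fall. The expected step is a number 12.2 percentage points higher from compound 2 to compound 4 (beyond the scatter). Compound 4 is therefore estimated at 25%, within a range from 5% to 60%.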

Compound 4, percent growth inhibition at one concentration: 87.7%
Compound 4: the middle estimate sits 62.7 percentage points below what was measured, outside the stated range (above it).
By their numbers in this assay, from the lowest: compound 2; then compounds 3, 1 and 4 (each within the scatter of the next).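

In this assay, among these compounds, the swap of morpholin-4-yl for pyrrolidin-1-yl on the thiocarbonyl carbon gives a number 74.9 percentage points higher from compound 2 to compound 4 (beyond the scatter) and is the first step to isolate this ring. On the core of compound 2, the ring at this place can therefore separate weak from strong inhibition of growth. No measurement shown here accounts for the step.

The compounds shown leave open whether ring size or the ring oxygen matters, which piperidin-1-yl on the same core could help separate. Going by these compounds, whether the swap has the same effect without the methyl group also remains open.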